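Amino for methyl on the shared core: compound 4

The compounds below may be only part of what the source reports. "The series", "measured", "known", "first", "only" and "open" are said of these compounds alone.

The series rests on one shared core. Compound 1 is `Nc1nc(N)c2c(-c3ccsc3)cn([C@@H]3O[C@H](CO)[C@@H](O)[C@H]3O)c2n1`, compound 2 is `Cc1nc(N)c2c(-c3cccs3)cn([C@@H]3O[C@H](CO)[C@@H](O)[C@H]3O)c2n1` and compound 3 is `Cc1nc(N)c2c(-c3ccsc3)cn([C@@H]3O[C@H](CO)[C@@H](O)[C@H]3O)c2n1`. In a functional assay on HL-60 cells (Homo sapiens) for antiproliferative activity, read by XTT assay, with a stated time of 72 h (a higher number here means a weaker inhibitor, a lower number a stronger inhibitor), compound 1 gives > 20000 nM, which is a limit of the assay and not a number. In this assay compound 2 gives > 20000 nM, likewise a limit. In this assay compound 3 gives > 20000 nM, again a limit. The step that the two limits leave unreadable from compound 1 to compound 3 and the step that the two limits leave unreadable from compound 2 to compound 3 therefore cannot be sized, since (the limit of > 20000 nM in this assay, at which 3 of the 3 values shown sit). Compound 4 is `Nc1nc(N)c2c(-c3cccs3)cn([C@@H]3O[C@H](CO)[C@@H](O)[C@H]3O)c2n1`; it differs from compound 2 by amino in place of methyl on an aromatic carbon. Among the measured compounds shown here, the only measured step of the same kind, from compound 1 to compound 3 in the reverse sense, stays hidden behind the limit, so nothing readable bears on the change. Compound 2 stands at the limit, and no movement beyond the scatter is expected from it. The expected step is a step that the limit leaves unreadable from compound 2 to compound 4. Compound 4 is expected to give 25000 nM in this assay, within 8000 nM to 80000 nM, most probably again as a limit.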

Compound 4, half-maximal inhibitory concentration: > 20000 nM
Compound 4 was reported as a limit; the forecaster's own chance of this, stated with the estimate: 85%; the middle value lies beyond the limit too.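

Neither compound 2 to compound 4 nor compound 1 to compound 4 gives a readable step, because all the values are limits and not numbers: the limit of > 20000 nM in this assay, at which 4 of the 4 values shown sit.

The compounds shown leave open whether amino versus methyl, or thiophen-2-yl versus thiophen-3-yl, changes antiproliferative activity on the shared core.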